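Swapping nitro for chloro on a thiazolidinone series

This account rests on a few compounds, and the source may have more. Where it says the series, first, only, none or still open, it means among the compounds named here.

Measured compounds:
- compound 1, `O=C1CSC(c2c(Cl)cccc2Cl)N1CCN1CCCCC1`: 76%
- compound 2, `O=C1CSC(c2ccc([N+](=O)[O-])cc2)N1CCN1CCCCC1`: 87%
- compound 3, `COc1cccc(C2SCC(=O)N2CCN2CCCCC2)c1`: 84%

Of the compounds shown here, three sharing one core have been tested in an ADME assay on Vero cells (Chlorocebus sabaeus) for cytotoxicity, read by neutral red uptake, tested at 98 ug/mL; on this read-out lower numbers stand for a stronger effect and higher numbers for a weaker effect at the one concentration tested. Compound 2 gives the highest number of the three, 87%, and compound 3 sits within the scatter of it with 84%. Compound 1 gives 76%. The gap between compound 2 and compound 1 lies beyond the scatter, compound 1 having the lower number. All three numbers sit in the upper part of the scale, so none of the compounds shows a strong effect at the one concentration tested.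

The next compound, compound 4, `O=C1CSC(c2ccc(Cl)cc2)N1CCN1CCCCC1`, differs from compound 2 in a single spot: chloro in place of nitro on an aromatic carbon. Among the compounds with values here, no pair of the measured compounds differs in only one place, so there is no measured step to lean on. A step in this assay from compound 2 to compound 4 of about a number 5 percentage points lower from compound 2 to compound 4 (within the scatter) is expected, which would stay within the scatter. For compound 4 the expected value is 82%, with a range from 70% to 94%.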

Compound 4, a percentage reported as activity, at one concentration (the size of the read-out at that concentration, not a potency): 74%
For compound 4 the middle estimate is 8 percentage points above the measured one; the range from low to high includes it.
By their numbers in this assay, from the lowest: compounds 4, 1, 3 and 2 (each within the scatter of the next, the first and the last beyond it).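

In this assay, chloro in place of nitro on this aromatic carbon, para to a large group, gives a number 13 percentage points lower from compound 2 to compound 4 (beyond the scatter). Within the data shown here, this is the only single-place change available here, and it shows that the group at this position can shift the read-out by more than the usual scatter, with chloro giving the stronger effect of the pair, although compound 4 still stands at 74%, so its effect at the one concentration tested remains modest. No measurement at hand accounts for this shift.

As far as these compounds go, it remains open whether other groups on this same carbon, such as an amine or a carboxylic acid, would give numbers closer to compound 2 or to compound 4. Compound 1 and compound 3 differ from this pair in more than one place, so they cannot show whether the same swap would have a similar effect elsewhere on the ring.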